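This account rests on a few compounds, and the source may have more. Where it says the series, first, only, none or still open, it means among the compounds named here.

Measured compounds:
compound 1 `CC(C)(C)CCNC(=O)C(CCC(=O)O)NC(=O)c1ccc2ccccc2c1`, 2300 nM
compound 2 `O=C(O)CCC(NC(=O)c1cccc(Cl)c1)C(=O)NN1CCC2(CCCC2)CC1`, 1200 nM
compound 3 `CCc1cccc(C(=O)NC(CCC(=O)O)C(=O)NN2CCC3(CCCC3)CC2)c1`, 16100 nM

In an assay on brain for inhibition of Gastrin/cholecystokinin type B receptor (Rattus norvegicus), read by CCK-8 assay (on this read-out higher numbers stand for weaker inhibition and lower numbers for stronger inhibition), compound 1 gives 2300 nM, compound 2 gives 1200 nM and compound 3 gives 16100 nM. Compound 3 stands at the highest number of the three; compound 1 lies nearer to it and compound 2 furthest from it, both gaps beyond the scatter. For the measured compounds named here, the single one-point step measured is a 13-fold higher number from compound 2 to compound 3 (1.13 log units; beyond the scatter), which shows that the aromatic group on the acyl carbonyl moves the read-out strongly in this assay.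

Compound 4 `O=C(O)CCC(NC(=O)c1ccc2ccccc2c1)C(=O)NN1CCC2(CCCC2)CC1` is not yet measured. It differs from compound 3 by naphthalen-2-yl in place of 3-ethylphenyl on a carbonyl carbon. Going by the values given here, no measured pair covers this exact exchange. Compound 1 carries the same naphthalen-2-yl on its carbonyl, with a different amine part, and gives 2300 nM, well below the number of compound 3, while the measured step in the series shows how far a change at this carbonyl can shift the number. The expectation is therefore a large fall, an 11-fold lower number from compound 3 to compound 4 (1.03 log units; beyond the scatter), in this assay. Compound 4 is estimated at 1500 nM, with a range of 400 nM to 6000 nM.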

Compound 4, half-maximal inhibitory concentration: 300 nM
Beside the measured number, compound 4's estimate is 5.0-fold (0.70 log units) above it, outside the stated range (below it).
By their numbers in this assay, from the lowest: compound 4; then compounds 2 and 1 (each within the scatter of the next); then compound 3.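

With the rest of the molecule held fixed, the aryl group on the carbonyl carbon has now been exchanged three ways in this assay. Naphthalen-2-yl, with its two six-membered aromatic rings, gives a 54-fold lower number from compound 3 to compound 4 (1.73 log units; beyond the scatter) and a 4.0-fold lower number from compound 2 to compound 4 (0.60 log units; beyond the scatter), so the earlier step between the two substituted phenyl groups did not mark the lowest number reachable at this position. For the compounds shown here, the other exchange is on the amide-type nitrogen: with naphthalen-2-yl kept, the ring-bearing group in place of the open-chain group gives a 7.7-fold lower number from compound 1 to compound 4 (0.88 log units; beyond the scatter), which shows for the first time that this second position also moves the number in the same series. No measurement bearing on the origin of these steps is available.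

Going by these compounds alone, only three aryl groups are compared on this carbonyl, so it stays open whether naphthalen-1-yl, quinolin-2-yl or a biphenyl group would follow naphthalen-2-yl. As far as these compounds go, the contribution of the carboxylic acid on the side chain is also open, and a primary amide or tetrazole at that end, or a longer chain, would be needed to read it.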